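A few compounds are considered here, and "the series" means these few. Any claim that something is new, unique, unknown or untested is made for them only; others in the source may bear on it.

In a functional assay on MDA-MB-231 cells (Homo sapiens) for antiproliferative activity, with a stated time of 48 h (a lower number here means a stronger inhibitor, a higher number a weaker inhibitor), compound 3 (`CCN(CC)c1ccc(-c2ccc(C(=O)O)cc2)nn1`) gives > 25000 nM as its entry, and this is a limit, not a number. Compound 1 (`CCN(CC)c1ccc(-c2ccc(C#N)cc2)nn1`) gives > 25000 nM as its entry, also a limit. Compound 2 (`CCN(CC)c1ccc(-c2ccc(C(=O)OC)cc2)nn1`) gives a true number of 140 nM in the same read-out.

Compound 4 (`CCOC(=O)c1ccc(-c2ccc(N(CC)CC)nn2)cc1`) differs from compound 3 by one change (ethyl in place of hydrogen on an oxygen next to a carbonyl group), which turns carboxy into ethoxycarbonyl. The nearest measured step is an at least 170-fold higher number from compound 2 to compound 3 (2.25 log units; beyond the scatter) for hydrogen in place of methyl on an oxygen next to a carbonyl group, and it is large. The new change runs the opposite way. The step of an at least 170-fold lower number from compound 1 to compound 2 (2.25 log units; beyond the scatter) is also large and likewise ends on the methoxycarbonyl compound. Ethyl against methyl on that oxygen is untested here.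

A large step towards a lower number, meaning stronger inhibition, is therefore expected, estimated as an at least 120-fold lower number from compound 3 to compound 4 (2.09 log units; beyond the scatter) in this assay overall. For compound 4 the estimated value is 200 nM with an expected range of 60 nM to 1500 nM in this read-out.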

Compound 4, half-maximal inhibitory concentration: 1500 nM
For compound 4 the middle estimate is 7.5-fold (0.88 log units) below the measured one, and the stated range covers the measured number.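

In this assay, activity at this position is not confined to the methoxycarbonyl group: ethoxycarbonyl also gives a true number, with an at least 16-fold lower number from compound 3 to compound 4 (1.22 log units; beyond the scatter) against the carboxy compound and an at least 16-fold lower number from compound 1 to compound 4 (1.22 log units; beyond the scatter) against the nitrile. The group on the ester oxygen also matters, since methyl in place of hydrogen on the saturated chain carbon bound to that oxygen gives an 11-fold higher number from compound 2 to compound 4 (1.03 log units; beyond the scatter). The two lower steps give minimum sizes only, as compound 1 and compound 3 are each entered as a limit: the limit of > 25000 nM in this assay, at which 2 of the 4 values shown sit.

Going by these compounds, whether a longer chain such as propyl, or a branched isopropyl group, on that oxygen continues the loss seen from methyl to ethyl remains open. Also open, on these data alone, is whether an amide in place of the ester keeps a true number in this read-out.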